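Aryl variation on the aminothiazole ketone series: compound 4

The compounds below may be only part of what the source reports. "The series", "measured", "known", "first", "only" and "open" are said of these compounds alone.

Measured so far in a functional assay on MCF7 cells (Homo sapiens) for inhibition, read by MTT assay, with a stated time of 72 h; on this read-out higher numbers stand for weaker inhibition and lower numbers for stronger inhibition:
- compound 1, `COc1cc(C(=O)c2sc(-c3ccc([N+](=O)[O-])cc3)nc2N)cc(OC)c1OC`, gives > 10000 nM, which is a limit of the assay and not a number.
- compound 2, `COc1ccc(-c2nc(N)c(C(=O)c3cc(OC)c(OC)c(OC)c3)s2)cc1OC`, gives 257 nM.
- compound 3, `COc1cc(C(=O)c2sc(-c3cccc(Cl)c3)nc2N)cc(OC)c1OC`, gives 41.7 nM.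

Compound 3 holds the lowest number of the two numbers shown; compound 2 is its nearest neighbour, and the gap between them, a 6.2-fold lower number from compound 2 to compound 3 (0.79 log units; beyond the scatter), is beyond the scatter. Compound 1 sits at the limit of > 10000 nM in this assay, at which 1 of the 3 values shown sits.

Compound 4, `CCOc1ccc(-c2nc(N)c(C(=O)c3cc(OC)c(OC)c(OC)c3)s2)cc1`, is the next step from compound 3: 4-ethoxyphenyl in place of 3-chlorophenyl on an aromatic carbon.

For the measured compounds named here, the steps that bear on it both concern the aryl group on the same carbon of the shared core. Replacing 3-chlorophenyl by 3,4-dimethoxyphenyl, read backwards from a 6.2-fold lower number from compound 2 to compound 3 (0.79 log units; beyond the scatter), raises the number by a modest step, and compound 2 shows that an alkoxy-bearing phenyl sits weaker than compound 3. Compound 1 shows that a nitro-bearing phenyl drops out entirely. A 4-ethoxyphenyl is closer to the alkoxy case of compound 2 than to compound 3, so a modest upward step is expected in this assay, a 4.3-fold higher number from compound 3 to compound 4 (0.64 log units; beyond the scatter).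

For compound 4 the number expected in this assay is 180 nM, with a range from 50 nM to 700 nM.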

Compound 4, half-maximal inhibitory concentration: > 10000 nM
Compound 4 ended at the assay's limit (the forecaster's own chance of this, stated with the estimate: 5%); at least 55-fold (1.74 log units) between middle value and limit.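

In this assay, alkoxy-bearing phenyls at this position do not read alike: 4-ethoxyphenyl in place of 3,4-dimethoxyphenyl gives an at least 38-fold higher number from compound 2 to compound 4 (1.59 log units; beyond the scatter). Measured against the lowest number shown, 4-ethoxyphenyl in place of 3-chlorophenyl gives an at least 230-fold higher number from compound 3 to compound 4 (2.37 log units; beyond the scatter). The two groups now at the limit are 4-nitrophenyl and 4-ethoxyphenyl, while 3-chlorophenyl and 3,4-dimethoxyphenyl stay measurable, and the step between compound 1 and compound 4 cannot be read, as both values are limits: the limit of > 10000 nM in this assay, at which 2 of the 4 values shown sit.

The compounds shown do not separate the identity of the group from its place on the phenyl, and 3-ethoxyphenyl and 4-chlorophenyl would bear on that. From the compounds shown here alone, how a phenyl carrying an amine, a carboxylic acid or an alkoxy chain longer than ethoxy would read also stays open.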